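A carbon-only group replaces 1-acetylpiperidin-4-yl

The source may hold more compounds than are shown below. What is called first, only, known or untested is meant among the compounds shown, and "the series" means these compounds.

In an ADME assay on microsomes from liver (Homo sapiens) for metabolic stability, with a stated time of 10 min (a lower number here means that less of the compound is left, a higher number that more of the compound is left), compound 1 (`Cc1c(Cl)cccc1Oc1cccn2c(C3CCOCC3)nnc12`) gives 100% and compound 2 (`CC(=O)N1CCC(c2nnc3c(Oc4cccc(Cl)c4C)cccn23)CC1`) gives 87% as the lower of the two numbers. Compound 3 (`Cc1c(Cl)cccc1Oc1cccn2c(C34CCC(F)(CC3)CC4)nnc12`) carries, in place of the 1-acetylpiperidin-4-yl of compound 2, a group with 2 six-membered non-aromatic rings of carbon only (a group of 9 heavy atoms (8 carbon, 1 fluorine; 2 six-membered non-aromatic rings of carbon only) in place of a group of 9 heavy atoms (7 carbon, 1 nitrogen, 1 oxygen; one six-membered non-aromatic ring with 1 hetero atom), on an aromatic carbon). For the measured compounds named here, the one measured step at this place (a number 13 percentage points lower from compound 1 to compound 2 (beyond the scatter)) was modest and brought in no such group, so it offers only a weak guide. A small change is expected, estimated as a number 2 percentage points lower from compound 2 to compound 3 (within the scatter) at most a slight drop. In this assay the estimate for compound 3 is 85% (expected range 65% to 100%).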

Compound 3, percent of the compound remaining: 76%
Compound 3: the middle estimate sits 9 percentage points above what was measured; measured number inside the range.
By their numbers in this assay, from the lowest: compound 3; then compound 2; then compound 1.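

In this assay, this position also responds to a group of carbon and fluorine alone, which carries no hydrogen-bond acceptor: the change gives a number 11 percentage points lower from compound 2 to compound 3 (beyond the scatter) and a number 24 percentage points lower from compound 1 to compound 3 (beyond the scatter). Among the three compounds, the oxan-4-yl of compound 1 thus stands highest and the group of compound 3 lowest. Nothing measured here bears on the reason for this order. Whether the fluorine or the two-ring carbon frame accounts for the step stays open, as does the standing of a plain cyclohexyl or a piperidin-4-yl with a free amine.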